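A tert-butyl group replaces two chlorines

The compounds below may be only part of what the source reports. "The series", "measured", "known", "first", "only" and "open" are said of these compounds alone.

Three compounds share one core and differ only in the aromatic group attached to it. Compound 1 `CCCS(=O)(=O)Nc1ccc(F)c(C(=O)c2n[nH]c3ncc(-c4ccccc4C)cc23)c1F` carries a 2-methylphenyl, compound 2 `CCCS(=O)(=O)Nc1ccc(F)c(C(=O)c2n[nH]c3ncc(-c4ccc(N(C)C)cc4)cc23)c1F` a 4-(dimethylamino)phenyl, and compound 3 `CCCS(=O)(=O)Nc1ccc(F)c(C(=O)c2n[nH]c3ncc(-c4ccc(Cl)c(Cl)c4)cc23)c1F` a 3,4-dichlorophenyl. In an assay for binding affinity to dual specificity mitogen-activated protein kinase kinase 4 (Homo sapiens), read by KINOMEscan, tested at 100 nM (a higher number here means a weaker effect of the compound at the concentration tested, a lower number a stronger effect), compound 1 gives 7%, compound 2 gives 2.5%, and compound 3 gives 45%. Compound 3 thus stands highest of the three, which here means the weakest effect; the step of a number 38 percentage points higher from compound 1 to compound 3 (beyond the scatter) and the step of a number 42.5 percentage points higher from compound 2 to compound 3 (beyond the scatter) are both large, while the step of a number 4.5 percentage points lower from compound 1 to compound 2 (within the scatter) is not.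

Compound 4 `CCCS(=O)(=O)Nc1ccc(F)c(C(=O)c2n[nH]c3ncc(-c4ccc(C(C)(C)C)cc4)cc23)c1F` has not yet been measured. It differs from compound 3 in one place: 4-(tert-butyl)phenyl in place of 3,4-dichlorophenyl on an aromatic carbon. Within the data shown here, its single group sits at the same numbered position as the 4-(dimethylamino)phenyl of compound 2.

The two large steps that end at compound 3 bear on this change: each time the 3,4-dichlorophenyl was the group present, the number was far higher than with either other phenyl. Removing it is therefore expected to bring the number back down, so the step of a number 30 percentage points lower from compound 3 to compound 4 (beyond the scatter) is expected to be a decrease beyond the scatter. Compound 4 is estimated at 15%, with a range from 3% to 50%.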

Compound 4, a percentage reported as activity, at one concentration (the size of the read-out at that concentration, not a potency): 46%
The estimate for compound 4 lay 31 percentage points below the measured number, within the range that was stated.
By their numbers in this assay, from the lowest: compounds 2 and 1 (each within the scatter of the next); then compounds 3 and 4 (each within the scatter of the next).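

In this assay, the step to an all-carbon group gives a number 1 percentage points higher from compound 3 to compound 4 (within the scatter), so the two compounds cannot be told apart and the high number of compound 3 does not depend on its two chlorines. Within the same position, tert-butyl in place of dimethylamino gives a number 43.5 percentage points higher from compound 2 to compound 4 (beyond the scatter), and 4-(tert-butyl)phenyl in place of 2-methylphenyl gives a number 39 percentage points higher from compound 1 to compound 4 (beyond the scatter), so exchanging a single group on the phenyl is enough to produce a large step, and two quite different groups, 3,4-dichlorophenyl and 4-(tert-butyl)phenyl, now share the high end. No supporting measurement is available to explain these numbers.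

As far as these compounds go, what compound 1 and compound 2 have in common remains open, since a 2-methylphenyl and a 4-(dimethylamino)phenyl differ both in the group they carry and in where it sits on the ring. A plain phenyl, or a phenyl carrying an amine or a carboxylic acid, at this position would help show whether the low numbers belong to the dimethylamino and methyl groups or whether the high numbers belong to the chlorines and tert-butyl.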